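The compounds below may be only part of what the source reports. "The series", "measured", "known", "first", "only" and "open" are said of these compounds alone.

Measured so far:
compound 1, `C=CCn1c(SCC(=O)Nc2ccc(C(C)=O)cc2)nnc1-c1ccccc1`, which in a functional assay on the whole organism (strain albino) for inhibition, with Rattus norvegicus as the target, read by paw edema, with stated times of 30 min and 3 h, at a dose of 0.28 mmol/kg by the oral route (a higher number here means more inhibition at the dose given (going by the name of the read-out), a lower number less inhibition), gives 54%
compound 2, `CCn1c(SCC(=O)Nc2ccc(C(C)=O)cc2)nnc1-c1ccc(OC)c(OC)c1`, which in this assay gives 62%

Compound 2 stands highest of these two numbers, but its nearest neighbour, compound 1, lies only a short way lower, a gap that sits within the usual scatter of this kind of measurement. The two numbers therefore cannot be told apart with confidence. For the measured compounds named here, compound 1 and compound 2 also differ from each other in more than one place, so no single structural step between measured compounds is available to learn from.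

Compound 3, `C=CCn1c(SCC(=O)Nc2ccc(C(C)=O)cc2)nnc1-c1ccc(OC)c(OC)c1`, has not yet been measured. It differs from compound 2 in one place only: vinyl in place of methyl on a saturated chain carbon bound to an aromatic nitrogen

Going by the values given here, no measured pair isolates this change, so there is nothing to say which way it should move the read-out. The expected step in this assay is small, within the scatter, with no clear direction. Compound 3 is expected to give about 59%, somewhere between 46% and 72%. This estimate means an expected step of a number 3 percentage points lower from compound 2 to compound 3 (within the scatter), which is within the scatter.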

Compound 3, a percentage reported as inhibition, in the whole organism at one dose (the size of the read-out at that dose, not a potency): 58%
Compound 3: middle estimate off by 1 percentage points, on the high side; the measured number falls inside the stated range.
By their numbers in this assay, from the lowest: compounds 1, 3 and 2 (each within the scatter of the next).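

In this assay, replacing methyl with vinyl on a saturated chain carbon bound to an aromatic nitrogen, which turns ethyl into allyl, can now be read directly (a number 4 percentage points lower from compound 2 to compound 3 (within the scatter)), and at this position the two chains cannot be told apart at this dose. Compound 3 also isolates a second change, 3,4-dimethoxyphenyl in place of phenyl on an aromatic carbon (a number 4 percentage points higher from compound 1 to compound 3 (within the scatter)), and this difference is likewise too small to separate from the ordinary spread of repeated measurements. No other measurement accompanies these results to help interpret either step.

From the compounds shown here alone, neither change moves the read-out beyond the scatter, so it remains open whether any group at the first position would do so, such as a longer chain like butyl, a benzyl group or a chain ending in an amine. Going by these compounds, on the aromatic carbon, it is also open whether a different replacement for phenyl, such as a pyridine ring or a 4-chlorophenyl group, would give a clearer difference from compound 1.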